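A few compounds are considered here, and "the series" means these few. Any claim that something is new, unique, unknown or untested is made for them only; others in the source may bear on it.

Measured so far, in cytotoxicity on mouse macrophage-like cells:
compound 1 `O=C(N/N=C/c1ccccc1)c1cnccn1` — 100%
compound 2 `CCOc1ccc(/C=N/NC(=O)c2cnccn2)cc1` — 100%

Both values come from an ADME assay on J774 cells (Mus musculus) for cytotoxicity, read by MTT assay, with a stated time of 48 h, tested at 50 ug/mL; on this read-out lower numbers stand for a stronger effect and higher numbers for a weaker effect at the one concentration tested. Compound 1 gives 100% and compound 2 gives 100%, so compound 2 stands level with compound 1 at the digits shown. Going by the values given here, the one measured step, no change at the digits printed from compound 1 to compound 2 (within the scatter), ethoxy in place of hydrogen on an aromatic carbon, leaves the read-out unchanged within the scatter.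

Compound 3 `O=C(N/N=C/c1ccc(O)cc1)c1cnccn1` is not yet measured. It differs from compound 2 by hydrogen in place of ethyl on an oxygen on an aromatic ring. The measured step is the only one that touches this part of the molecule, and it was flat. Nothing in the data points to a shift in either direction in this assay, so the expected step is no change at the digits printed from compound 2 to compound 3 (within the scatter), none beyond the scatter. Compound 3 is therefore estimated at 100%, with a range of 88% to 110%.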

Compound 3, a percentage reported as activity, at one concentration (the size of the read-out at that concentration, not a potency): 100%
The estimate for compound 3 equals the measured number at the digits printed, within the range that was stated.
By their numbers in this assay, from the lowest: compounds 1, 2 and 3 (each within the scatter of the next).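

Working from the ethoxy group of compound 2, removing the ethyl from the oxygen on the aromatic ring gives no change at the digits printed from compound 2 to compound 3 (within the scatter) in this assay and exposes a free hydroxy for the first time in the series. Set against the unsubstituted ring, hydroxy in place of hydrogen gives no change at the digits printed from compound 1 to compound 3 (within the scatter) in this assay, so hydrogen, ethoxy and hydroxy at this place all read level at the one concentration tested. No information is available on why the read-out stays flat across these three compounds.

On these data alone, whether an amine, a carboxylic acid or a chain longer than ethyl on this oxygen would shift the read-out remains open. Also open is how any of these compounds would read at a higher concentration, or with a change elsewhere on the shared core.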